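The compounds below may be only part of what the source reports. "The series", "measured", "known", "first", "only" and "open" are said of these compounds alone.

Of the compounds shown here, three built on one shared core have been measured in an assay on brain for binding affinity to adenosine receptor A1 (Rattus norvegicus), read by radioligand binding; on this read-out higher numbers stand for weaker inhibition and lower numbers for stronger inhibition. Compound 1 `CCCn1c(=O)c2nc(-c3ccc(OCC(=O)NCCN=C(S)Nc4ccc(C)cc4)cc3)[nH]c2n(CCC)c1=O` carries a methyl group on its outermost aromatic ring and gives 16 nM. Compound 2 `CCCn1c(=O)c2nc(-c3ccc(OCC(=O)NCCN=C(S)Nc4ccc(OC)cc4)cc3)[nH]c2n(CCC)c1=O` carries a methoxy group in that place and gives 33.2 nM. Compound 3 `CCCn1c(=O)c2nc(-c3ccc(OCC(=O)NCCN=C(S)Nc4ccc(F)cc4)cc3)[nH]c2n(CCC)c1=O` carries a fluoro group there and gives 15.5 nM. The smallest of the three numbers belongs to compound 3, yet against compound 1 the difference is negligible, since a 1.0-fold lower number from compound 1 to compound 3 (0.01 log units; within the scatter). Only the methoxy compound stands apart: a 2.1-fold lower number from compound 2 to compound 3 (0.33 log units; beyond the scatter).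

Compound 4 `CCCn1c(=O)c2nc(-c3ccc(OCC(=O)NCCN=C(S)Nc4ccc(Br)cc4)cc3)[nH]c2n(CCC)c1=O` is the next member of the set, and it has not yet been measured. Its change from compound 3 is bromo in place of fluoro on an aromatic carbon. Among the compounds with values here, no measured step exchanges one halogen for another, so the only guidance comes from the two steps ending at compound 3, one of which was flat and the other modest. That record suggests a small movement at most. The step into compound 4 is therefore expected to be small, estimated as a 1.1-fold lower number from compound 3 to compound 4 (0.04 log units; within the scatter). Compound 4 is expected to give about 14 nM, with a likely range from 6 nM to 35 nM.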

Compound 4, inhibition constant: 7.26 nM
Beside the measured number, compound 4's estimate is 1.9-fold (0.29 log units) above it; measured number inside the range.
By their numbers in this assay, from the lowest: compound 4; then compounds 3 and 1 (each within the scatter of the next); then compound 2.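

In this assay the identity of the halogen matters at this position on the outer six-membered ring, with a 2.1-fold lower number from compound 3 to compound 4 (0.33 log units; beyond the scatter) for a swap of one single atom for another, neither of which adds a hydrogen-bond donor, acceptor or charge. Within the data shown here, until now, methyl and fluoro could not be told apart here, and only the methoxy compound stood apart, so the position looked fairly tolerant; bromo is the first group to move the number down beyond the scatter, with a 2.2-fold lower number from compound 1 to compound 4 (0.34 log units; beyond the scatter) and a 4.6-fold lower number from compound 2 to compound 4 (0.66 log units; beyond the scatter) making compound 4 the most potent of the four in this assay. Nothing available explains why bromo behaves differently from fluoro here.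

Going by these compounds, with only two halogens in hand, it remains open whether chloro or iodo would fall in line with either of them, and so whether any trend runs through the halogens at all. Also open, on these data alone, is how a nitrile, a trifluoromethyl group or an amine would behave at this position, and whether bromo would give a similar gain on another carbon of the same ring.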